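Swapping methoxy for fluoro on the pendant phenyl ring

A few compounds are considered here, and "the series" means these few. Any claim that something is new, unique, unknown or untested is made for them only; others in the source may bear on it.

Measured compounds:
compound 1 `Brc1cn2ccnc2c(-c2ccc3ncn(C4CCCCC4)c3c2)n1`: 18%
compound 2 `CC(=O)c1ccc(-c2cn3ccnc3c(-c3ccc4ncn(C5CCCCC5)c4c3)n2)cc1`: 2.65%
compound 3 `COc1ccccc1-c1cn2ccnc2c(-c2ccc3ncn(C4CCCCC4)c3c2)n1`: 14.6%

In a functional assay on HL-60 cells (Homo sapiens) for inhibition, read by sulforhodamine B assay, with a stated time of 48 h, tested at 10 uM (on this read-out higher numbers stand for more inhibition at the one concentration tested (going by the name of the read-out) and lower numbers for less inhibition), compound 3 sits second highest of the three, within the scatter of compound 1 and beyond it only against compound 2. Compound 4 `Fc1ccccc1-c1cn2ccnc2c(-c2ccc3ncn(C4CCCCC4)c3c2)n1` differs from compound 3 by fluoro in place of methoxy on an aromatic carbon. Going by the values given here, no measured step swaps one small group on that phenyl ring for another; the nearest comparisons exchange the whole group at this position: a number 3.4 percentage points lower from compound 1 to compound 3 (within the scatter) and a number 12 percentage points higher from compound 2 to compound 3 (beyond the scatter). Both stay small or modest, and all three values are low. The step of a number 1.6 percentage points lower from compound 3 to compound 4 (within the scatter) is therefore expected to stay within the scatter. Compound 4 is estimated at 13%, with a range from 2% to 26%.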

Compound 4, a percentage reported as inhibition, at one concentration (the size of the read-out at that concentration, not a potency): 9.3%
Beside the measured number, compound 4's estimate is 3.7 percentage points above it; the range from low to high includes it.
By their numbers in this assay, from the lowest: compounds 2, 4, 3 and 1 (each within the scatter of the next, the first and the last beyond it).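

In this assay, the one small swap shown on this phenyl ring, fluoro in place of methoxy, gives a number 5.3 percentage points lower from compound 3 to compound 4 (within the scatter), so the read-out does not separate these two groups here. Compound 4 also stays close to both other compounds, with a number 6.7 percentage points higher from compound 2 to compound 4 (within the scatter) and a number 8.7 percentage points lower from compound 1 to compound 4 (within the scatter), even though those two lie beyond the scatter of each other. No measured evidence bears on these numbers.

From the compounds shown here alone, whether an amine or a carboxylic acid in place of fluoro would move the number beyond the scatter stays open.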